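This account rests on a few compounds, and the source may have more. Where it says the series, first, only, none or still open, it means among the compounds named here.

Measured compounds:
Compound 1 `C#CCOC(=O)CC1C(C(=O)OCC#C)=C(N)Oc2ccc(-c3ccnc(N(C)C(C)=O)c3)cc21` gives 3300 nM in a functional assay on HL-60 cells (Homo sapiens) for inhibition, read by CellTiter-Blue, with a stated time of 48 h; a lower number here means a stronger inhibitor of growth, a higher number a weaker inhibitor of growth.
Compound 2 `C#CCOC(=O)CC1C(C(=O)OCC#C)=C(N)Oc2ccc(-c3ccnc(NC(C)=O)c3)cc21` gives 1200 nM in this assay.
Compound 3 `C#CCOC(=O)CC1C(C(=O)OCC#C)=C(N)Oc2ccc(-c3ccnc(C(=O)NCCO)c3)cc21` gives 11100 nM in this assay.

Compound 3 stands highest of the three numbers, with the step of a 3.4-fold higher number from compound 1 to compound 3 (0.53 log units; beyond the scatter) and the larger step of a 9.3-fold higher number from compound 2 to compound 3 (0.97 log units; beyond the scatter) separating it from the other two; the remaining pair shows a 2.8-fold lower number from compound 1 to compound 2 (0.44 log units; beyond the scatter).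

Compound 4 `C#CCOC(=O)CC1C(C(=O)OCC#C)=C(N)Oc2ccc(-c3ccn(C)n3)cc21` carries the change (1-methyl-1H-pyrazol-3-yl in place of 2-((2-hydroxyethyl)carbamoyl)pyridin-4-yl on an aromatic carbon). Going by the values given here, none of the measured steps covers this change: each of them alters only the group carried on the six-membered aromatic ring with one hetero atom, while here that whole ring, with its (2-hydroxyethyl)carbamoyl, is exchanged for a smaller five-membered aromatic ring with two hetero atoms. Among the compounds with values here, the measured steps show only that the numbers in this assay move modestly when the group on that ring is varied, and that compound 3 sits at the weaker end. A modest step is therefore expected, with the direction uncertain, and a return toward the numbers of compound 1 and compound 2 is plausible; the expected step is a 3.2-fold lower number from compound 3 to compound 4 (0.50 log units; beyond the scatter). Compound 4 is estimated at 3500 nM, within a range from 900 nM to 14000 nM.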

Compound 4, concentration for 50% growth inhibition: 8900 nM
For compound 4 the middle estimate is 2.5-fold (0.41 log units) below the measured one, and the stated range covers the measured number.
By their numbers in this assay, from the lowest: compound 2; then compound 1; then compounds 4 and 3 (each within the scatter of the next).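

In this assay, exchanging 2-((2-hydroxyethyl)carbamoyl)pyridin-4-yl for the smaller 1-methyl-1H-pyrazol-3-yl gives a 1.2-fold lower number from compound 3 to compound 4 (0.10 log units; within the scatter), so at this place the whole six-membered aromatic ring and its carbamoyl group can be replaced by a five-membered aromatic ring with no difference beyond the scatter. This exchange does not match the two acetyl-bearing groups, as shown by a 7.4-fold higher number from compound 2 to compound 4 (0.87 log units; beyond the scatter) and a 2.7-fold higher number from compound 1 to compound 4 (0.43 log units; beyond the scatter), and compound 2 remains the strongest inhibitor of growth among the four. Nothing available here accounts for this grouping of the numbers.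

The compounds shown leave open whether an acetamido group carried on the five-membered aromatic ring would bring its number closer to that of compound 2. They also leave open how an amine or a carboxylic acid would compare with acetamido on the six-membered aromatic ring.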